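The compounds below may be only part of what the source reports. "The series", "measured", "known", "first", "only" and "open" are said of these compounds alone.

Measured in a functional assay on HCT-116 cells (Homo sapiens) for antiproliferative activity, read by MTT assay, with a stated time of 72 h; on this read-out lower numbers stand for stronger inhibition of growth and higher numbers for weaker inhibition of growth:

- Compound 1 `Cc1c(C(=O)Nc2ccc(SC#N)cc2)nnn1-c1ccc(C(C)C)cc1`: > 100000 nM, a limit
- Compound 2 `Cc1ccc(-n2nnc(C(=O)Nc3ccc(SC#N)cc3)c2C)cc1C`: > 100000 nM, a limit

Compound 2 has no exact number, only a limit of > 100000 nM. The other compound offers no firmer reference point, and the picture so far is the limit of > 100000 nM in this assay, at which 2 of the 2 values shown sit.

Compound 3 `Cc1ccc(Cl)cc1-n1nnc(C(=O)Nc2ccc(SC#N)cc2)c1C` keeps the shared core and changes one group, with 5-chloro-2-methylphenyl in place of 3,4-dimethylphenyl on an aromatic nitrogen. The new group sits on the ring nitrogen next to the ring atom that bears a methyl group.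

Among the compounds with values here, the only measured step that bears on this change is a step that the two limits leave unreadable from compound 1 to compound 2. It also exchanges one substituted phenyl group for another at the same nitrogen, but it gives no readable size. With no measured gain to build on, the working expectation in this assay is no clear movement in either direction, although a measurable value cannot be ruled out.

The estimated change is a number no higher from compound 2 to compound 3 (the limit leaves the size open). For compound 3 the expected value is 100000 nM, with an estimated range from 25000 nM to 200000 nM.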

Compound 3, concentration for 50% growth inhibition: 39600 nM
Beside the measured number, compound 3's estimate is 2.5-fold (0.40 log units) above it, within the range that was stated.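

In this assay, the group on the aromatic nitrogen proves able to move the read-out: 5-chloro-2-methylphenyl in place of 3,4-dimethylphenyl gives an at least 2.5-fold lower number from compound 2 to compound 3 (0.40 log units; beyond the scatter), and the same group in place of 4-isopropylphenyl gives an at least 2.5-fold lower number from compound 1 to compound 3 (0.40 log units; beyond the scatter). Within the data shown here, the earlier exchange at this nitrogen, between compound 1 and compound 2, cannot be read, so these are the first steps at this position with any size, and both sizes stay open-ended since each starts from a limit. Most of the compounds shown still sit at one limit: the limit of > 100000 nM in this assay, at which 2 of the 3 values shown sit.

Compound 3 differs from compound 2 in both the chlorine and the placing of the methyl groups on the phenyl ring, so the compounds shown cannot separate what each of these contributes to the step. On these data alone, it also remains open how a phenyl ring carrying only the chlorine would behave, or whether a bromine or a methoxy group in the chlorine's place would lower the number further.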